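The compounds below may be only part of what the source reports. "The series", "measured", "known", "first", "only" and "open" are said of these compounds alone.

Measured in a physicochemical assay for solubility, in phosphate buffer, with a stated time of 18 h, at pH 7.4; a higher number here means a more soluble compound, a lower number a less soluble compound:
- Compound 1 `COCCOc1cc2c(-n3nc(-c4ccccn4)nc3N)ncnc2cc1OC`: 8000 nM
- Compound 2 `COc1cc2ncnc(-n3nc(-c4ccccn4)nc3N)c2cc1OCCCNC(=O)OC(C)(C)C`: 2000 nM
- Compound 3 `COc1cc2ncnc(-n3nc(-c4ccccn4)nc3N)c2cc1OCCCCNC(=O)OC(C)(C)C`: 500 nM

Compound 3 has the lowest number of the three. Compound 4 `COc1cc2ncnc(-n3nc(-c4ccccn4)nc3N)c2cc1OCCCNC(=O)OC(C)C` differs from it by (isopropoxycarbonyl)amino in place of ((tert-butoxycarbonyl)amino)methyl on a saturated chain carbon, three bonds along the chain from an oxygen on an aromatic ring. Cut further out, this reads 4-((tert-butoxycarbonyl)amino)butyl to 3-((isopropoxycarbonyl)amino)propyl. The closest measured step is the modest 4.0-fold lower number from compound 2 to compound 3 (0.60 log units; beyond the scatter), which runs the opposite way along the chain. The large 16-fold lower number from compound 1 to compound 3 (1.20 log units; beyond the scatter) points the same way. Within the data shown here, no measured step isolates isopropoxycarbonyl against tert-butoxycarbonyl, so that part remains open. A modest to large rise in this assay is therefore expected, an estimated 6.0-fold higher number from compound 3 to compound 4 (0.78 log units; beyond the scatter). Compound 4 is estimated at 3000 nM, with an expected range of 1000 nM to 9000 nM.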

Compound 4, solubility: 18000 nM
For compound 4 the middle estimate is 6.0-fold (0.78 log units) below the measured one; measured number above the stated range.
By their numbers in this assay, from the lowest: compound 3; then compound 2; then compound 1; then compound 4.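

In this assay, among these compounds, hydrogen in place of methyl on the saturated chain carbon bound to an oxygen next to a carbonyl group gives a 9.0-fold higher number from compound 2 to compound 4 (0.95 log units; beyond the scatter) and is the first step here to alter the end of the chain rather than its length. With the propyl chain as well, the change from the butyl chain gives a 36-fold higher number from compound 3 to compound 4 (1.56 log units; beyond the scatter) and the methoxy chain is also passed, with a 2.3-fold higher number from compound 1 to compound 4 (0.35 log units; beyond the scatter) showing that a longer substituent need not give a lower number. No evidence given here accounts for these steps. Going by these compounds, whether the same hydrogen for methyl change holds on the butyl chain remains open, as does the effect of a free amine in place of the isopropoxycarbonyl amino group.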